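Dimethyl pair in the whole-animal series

A few compounds are considered here, and "the series" means these few. Any claim that something is new, unique, unknown or untested is made for them only; others in the source may bear on it.

Two diaryl compounds on the shared core have been taken through a functional assay on the whole organism (Cricetulus griseus) with Cricetinae gen. sp. as the target; on this read-out lower numbers stand for an effect already at smaller amounts and higher numbers for an effect only at larger amounts of compound. Compound 1 `Cc1ccccc1-c1n[nH]c(-c2ccccc2)n1` carries one methyl-bearing ring and one unsubstituted ring; in this assay compound 1 gives 10 mg/kg. Compound 2 `COc1ccccc1-c1n[nH]c(-c2ccccc2C)n1` carries a methoxy-bearing ring in place of the unsubstituted one. For compound 2 this assay reports only a limit and not a number, > 5 mg/kg. Compound 2 therefore stands at the limit of > 5 mg/kg in this assay, at which 1 of the 2 values shown sits, so its position relative to compound 1 cannot be read from the numbers shown. For the measured compounds named here, no step between measured compounds is available for comparison.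

The next compound, compound 3 `Cc1ccccc1-c1n[nH]c(-c2ccccc2C)n1`, differs from compound 2 by one change: methyl in place of methoxy on an aromatic carbon. Going by the values given here, what is known gives no measured step for such an exchange, and the limit on compound 2 leaves its own value open. The expected step is a step that the limit leaves unreadable from compound 2 to compound 3, no larger than the usual scatter. On that basis compound 3 is estimated at 10 mg/kg in this assay, with a range from 4 mg/kg to 30 mg/kg, guided by the value of compound 1 at 10 mg/kg.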

Compound 3, dose for half-maximal effect: > 10 mg/kg
Compound 3 was reported as a limit; the forecaster's own chance of this, stated with the estimate: 40%; the middle value lies on the limit itself.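

In this assay compound 3 is reported only as a limit (> 10 mg/kg). Methyl in place of hydrogen on an aromatic carbon gives (a number no lower from compound 1 to compound 3 (the limit leaves the size open)), so this second methyl does not bring the effect to a smaller dose on this read-out. The size of the exchange of methoxy for methyl, ortho to a large group, cannot be read, and nothing measured here speaks to a cause for the result.

As far as these compounds go, how far compound 3 lies from compound 1 stays open, as does the true value of compound 3. Also open, from the compounds shown here alone, is whether an amine or a chlorine on this aromatic carbon would give a number rather than a limit in this assay.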